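The source may hold more compounds than are shown below. What is called first, only, known or untested is meant among the compounds shown, and "the series" means these compounds.

Of the compounds shown here, three built on one shared core have been measured, and a fourth awaits measurement. Compound 1 `CCCCCn1c(-c2ccccc2)nc2c(N)ccnc21` carries a phenyl group on the core and a plain amino group. Compound 2 `CCCCCn1c(-c2ccco2)nc2c(N)ccnc21` differs from compound 1 by furan-2-yl in place of phenyl on an aromatic carbon. Compound 3 `CCCCCn1c(-c2ccccc2)nc2c(NCCCO)ccnc21` differs from compound 1 by 3-hydroxypropyl in place of hydrogen on a nitrogen on an aromatic ring, so the core of compound 3 is the core of compound 1 with that change.

In an assay on isolated protein for inhibition of high affinity 3',5'-cyclic-AMP phosphodiesterase 7A (Homo sapiens), read by cAMP accumulation, with a stated time of 20 min (a higher number here means a weaker inhibitor, a lower number a stronger inhibitor), compound 1 gives > 200000 nM, which is a limit of the assay rather than a number. In this assay compound 2 gives > 200000 nM, again a limit. In this assay compound 3 gives > 200000 nM, once more a limit. The step that the two limits leave unreadable from compound 1 to compound 2 therefore cannot be sized, and the same holds for a step that the two limits leave unreadable from compound 1 to compound 3, because of the limit of > 200000 nM in this assay, at which 3 of the 3 values shown sit.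

Compound 4 `CCCCCn1c(-c2ccco2)nc2c(NCCCO)ccnc21` has not been measured yet. Among the compounds with values here, it differs from compound 3 by furan-2-yl in place of phenyl on an aromatic carbon, the same change, at the same place, as the one from compound 1 to compound 2. Set beside a step that the two limits leave unreadable from compound 1 to compound 2, the step expected here is a step that the limit leaves unreadable from compound 3 to compound 4, an expectation that rests on (the limit of > 200000 nM in this assay, at which 3 of the 3 values shown sit), so that no measurable movement can be predicted from the change alone. Compound 4 is expected to sit near 300000 nM in this assay, with a plausible range from 100000 nM to 1000000 nM, most likely reported again as a limit.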

Compound 4, half-maximal inhibitory concentration: 63600 nM
Estimate against measurement, compound 4: 4.7-fold (0.67 log units) above, outside the stated range (below it).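

Carrying furan-2-yl in place of phenyl onto the core of compound 3 gives a real, readable result in this assay: an at least 3.1-fold lower number from compound 3 to compound 4 (0.49 log units; beyond the scatter). Within the data shown here, this does not show that the change acts in the same way on both cores, since the matching step on the core of compound 1 cannot be sized, and neither can the step that adds 3-hydroxypropyl to compound 1: the limit of > 200000 nM in this assay, at which 3 of the 4 values shown sit. The other route to compound 4, adding 3-hydroxypropyl to the core of compound 2, gives an at least 3.1-fold lower number from compound 2 to compound 4 (0.49 log units; beyond the scatter), so compound 4, which joins both changes, is the only compound here with a true number, and each of these two steps gives only a minimum size, which leaves open whether either change alone does anything and whether the two together do more than their sum.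

Among these compounds, the four compounds cover only two groups on the aromatic carbon and two on the nitrogen, so they cannot tell whether the trend would hold with another ring such as thiophene on the carbon. They also leave open what a longer chain or an amine in place of 3-hydroxypropyl would do alongside furan-2-yl.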